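Propargylthio triazole phthalimides: compound 1 and a propyl homologue

The source may hold more compounds than are shown below. What is called first, only, known or untested is meant among the compounds shown, and "the series" means these compounds.

Compound 1, `C#CCSc1nnc(CC)n1N1C(=O)c2ccccc2C1=O`: in a functional assay on PC-3M cells (Homo sapiens) for cytotoxicity, read by MTT assay, with a stated time of 48 h (a lower number here means a stronger inhibitor, a higher number a weaker inhibitor), compound 1 gives > 200000 nM, which is a limit of the assay rather than a number.
Compound 2, `CCc1nnc(SCC(=O)c2ccc(Cl)cc2)n1N1C(=O)c2ccccc2C1=O`: in this assay compound 2 gives > 200000 nM, likewise a limit.

Compound 1 therefore stands at the limit of this assay, with no measured number of its own. For the measured compounds named here, the one measured step, a step that the two limits leave unreadable from compound 1 to compound 2, cannot be read, because of the limit of > 200000 nM in this assay, at which 2 of the 2 values shown sit. The change to compound 3, `C#CCSc1nnc(CCC)n1N1C(=O)c2ccccc2C1=O`, is methyl in place of hydrogen on a saturated chain carbon, two bonds along the chain from an aromatic carbon. Going by the values given here, no measured step bears on this change, and the single step that was measured gives no size at all, so no direction can be taken from it; compound 3 is expected to stay at the limit of this assay. The step from compound 1 to compound 3 is estimated as a step that the limit leaves unreadable from compound 1 to compound 3. For compound 3 the estimate in this assay is 250000 nM, within 60000 nM to 1000000 nM.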

Compound 3, half-maximal inhibitory concentration: > 200000 nM
Compound 3: only a limit was reported (the forecaster's own chance of this, stated with the estimate: 85%); the middle value does not contradict the limit.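

For the compounds shown here, compound 3, like compound 1, stands only at a limit in this assay, so no step between compound 1 and compound 3 can be read: the limit of > 200000 nM in this assay, at which 3 of the 3 values shown sit.

The compounds shown leave open whether going from ethyl to propyl changes cytotoxicity at all, and what real potency any of them has.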